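Reversing the Side-Chain Amide of Compound 3

The compounds below may be only part of what the source reports. "The series", "measured", "known", "first", "only" and "open" are said of these compounds alone.

Measured compounds in a functional assay on CHO cells for antagonist activity at Orexin/Hypocretin receptor type 1 (Homo sapiens), read by FLIPR; on this read-out lower numbers stand for stronger inhibition and higher numbers for weaker inhibition:
compound 1, `COc1cccc(C(=O)N2CCCCC2CCOc2ccc(Cl)c(Cl)c2)c1`, gives 126 nM
compound 2, `O=C(c1ccccc1-c1ccccc1)N1CCCC[C@H]1CCOc1ccc(F)cc1F`, gives 0.159 nM
compound 3, `O=C(NC[C@@H]1CCCCN1C(=O)c1ccccc1-c1ccccc1)c1ccccc1`, gives 7.94 nM

Compound 3 stands second highest of the three numbers in this assay; its nearest neighbour is compound 1, and the furthest is compound 2. For the measured compounds named here, the single change that leads to compound 3, a 50-fold higher number from compound 2 to compound 3 (1.70 log units; beyond the scatter), shows that what hangs on the saturated chain carbon bound to the saturated ring carbon matters greatly.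

Compound 4, `O=C(C[C@@H]1CCCCN1C(=O)c1ccccc1-c1ccccc1)Nc1ccccc1`, keeps the same atoms as compound 3 but joins them differently: phenylcarbamoyl in place of benzamido on a saturated chain carbon bound to a saturated ring carbon. Going by the values given here, no measured step in this set turns an amide around in this way, so the direction is open. Among the compounds with values here, the one step on this part of the structure was large, and a reversed amide is expected to change the number by a moderate amount rather than leave it untouched. Compound 4 is therefore expected to show a 3.1-fold higher number from compound 3 to compound 4 (0.50 log units; beyond the scatter) in this assay, as a weaker number is judged more likely than a stronger one. The estimate for compound 4 is 25 nM, with a range from 5 nM to 150 nM.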

Compound 4, inhibition constant: 50.1 nM
For compound 4 the middle estimate is 2.0-fold (0.30 log units) below the measured one; measured number inside the range.
By their numbers in this assay, from the lowest: compound 2; then compound 3; then compound 4; then compound 1.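

In this assay, turning the amide around gives a 6.3-fold higher number from compound 3 to compound 4 (0.80 log units; beyond the scatter), although the two groups have the same atoms and the same counts of hydrogen-bond donors and acceptors; on a saturated chain carbon bound to a saturated ring carbon, the direction of the amide therefore matters as well as its composition. The comparison with the ether side chain widens to a 320-fold higher number from compound 2 to compound 4 (2.50 log units; beyond the scatter), and neither amide orientation comes close to compound 2. Nothing here offers an explanation for the difference between the two orientations.

As far as these compounds go, it remains open whether a urea or a sulfonamide at this place would behave like either amide. The compounds shown also leave open whether a 2,4-difluorophenyl group on the phenylcarbamoyl nitrogen would narrow the gap to compound 2.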